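Para-Fluoro Change on a Core Known Only by Limits

A few compounds are considered here, and "the series" means these few. Any claim that something is new, unique, unknown or untested is made for them only; others in the source may bear on it.

Compound 1 `CCOC(=O)[C@@H]1C(=O)N(Cc2ccccc2)C[C@@H](O)[C@H]1c1ccccc1` is known only as a limit of the assay: in a physicochemical assay, with a stated time of 60 min (a higher number here means a weaker inhibitor, a lower number a stronger inhibitor), compound 1 gives > 100000 nM. Compound 2 `CCOC(=O)[C@@H]1C(=O)N(Cc2ccccc2)CC[C@H]1c1ccccc1` likewise sits at a limit, giving > 100000 nM in this assay. Compound 3 `OC[C@@H]1CN(Cc2ccccc2)CC[C@H]1c1ccccc1` also reaches only a limit, with > 100000 nM in this assay. For the measured compounds named here, the one step among them, a step that the two limits leave unreadable from compound 1 to compound 2, stays unreadable because of the limit of > 100000 nM in this assay, at which 3 of the 3 values shown sit. Compound 4 `CCOC(=O)[C@@H]1C(=O)N(Cc2ccccc2)C[C@@H](O)[C@H]1c1ccc(F)cc1` differs from compound 1 by fluoro in place of hydrogen on an aromatic carbon. Going by the values given here, no measured step bears on that change, and every value shown is a limit. Compound 4 is therefore expected to remain at the limit, its estimate being 200000 nM with a range from 50000 nM to 1000000 nM. The step that the limit leaves unreadable from compound 1 to compound 4 is thus expected to show no readable size.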

Compound 4, half-maximal inhibitory concentration: > 100000 nM
Compound 4: only a limit was reported (the forecaster's own chance of this, stated with the estimate: 85%); the middle value lies beyond the limit too.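

No new step can be read between compound 1 and compound 4, because both stand at a limit: the limit of > 100000 nM in this assay, at which 4 of the 4 values shown sit.

The compounds shown leave open whether phenyl to 4-fluorophenyl alters inhibition at all, and what change to the shared core would give a measurable value in this assay.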